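Triazine series: anilino in place of methoxy

This account rests on a few compounds, and the source may have more. Where it says the series, first, only, none or still open, it means among the compounds named here.

Compound 1 `CNc1nc(NC)nc(NC2(C#N)CCCCC2)n1`: in an in vitro assay on Sf21 cells for inhibition of high affinity 3',5'-cyclic-AMP phosphodiesterase 7A (Homo sapiens) (a lower number here means a stronger inhibitor, a higher number a weaker inhibitor), compound 1 gives > 1000 nM, which is a limit of the assay.
Compound 2 `CNc1nc(NC2(C#N)CCCCC2)nc(OC)n1`: in this assay compound 2 gives 521 nM.

Within the data shown here, compound 2 holds the only numerical value in this assay; the other entry is a limit. The step of an at least 1.9-fold lower number from compound 1 to compound 2 (0.28 log units; that floor lies within the scatter) rests on that limit of > 1000 nM in this assay, at which 1 of the 2 values shown sits, and sets only a floor. Compound 3 `CNc1nc(Nc2ccccc2)nc(NC2(C#N)CCCCC2)n1` differs from compound 2 by anilino in place of methoxy on an aromatic carbon. Among the measured compounds shown here, no measured step touches anilino, so the single step bears on it only weakly. For compound 3 the step of a 1.0-fold lower number from compound 2 to compound 3 (0.02 log units; within the scatter) is expected to stay within the scatter. The estimate for compound 3 is 500 nM, range 150 nM to 1500 nM.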

Compound 3, half-maximal inhibitory concentration: > 5000 nM
Compound 3 ended at the assay's limit; the forecaster's own chance of this, stated with the estimate: 25%; middle value at least 10-fold (1.00 log units) away from the limit.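

Among these compounds, at this position, opposite the ring nitrogen, anilino in place of methoxy gives an at least 9.5-fold higher number from compound 2 to compound 3 (0.98 log units; beyond the scatter), the first step that is printed as beyond the scatter. In this assay compound 3 gives > 5000 nM, which is a limit, so the step sets only a floor: the limit of > 5000 nM in this assay, at which 1 of the 3 values shown sits. The step between compound 1 and compound 3 cannot be read.

From the compounds shown here alone, it remains open whether the phenyl ring or its linking nitrogen accounts for the higher number. Phenoxy or benzyloxy at this position would separate the two, and ethoxy would test a small extension of methoxy.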